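Expectation for Compound 4 Against a Liver Cell Line

A few compounds are considered here, and "the series" means these few. Any claim that something is new, unique, unknown or untested is made for them only; others in the source may bear on it.

Three measured compounds share one core. Compound 1 `O=C(N/N=C/c1ccc(F)cc1)Nc1cc2c(Nc3ccc(F)c(Cl)c3)ncnc2cc1O[C@H]1CCOC1` is recorded as "not active" (no number reported) in a functional assay on HepG2 cells (Homo sapiens) for cytotoxicity, read by MTT assay, with a stated time of 72 h (on this read-out higher numbers stand for weaker inhibition and lower numbers for stronger inhibition), with no number reported. Compound 2 `N#Cc1ccc(/C=N/NC(=O)Nc2cc3c(Nc4ccc(F)c(Cl)c4)ncnc3cc2O[C@H]2CCOC2)cc1` gives 26400 nM in this assay, the lowest of the two numbers reported there, while compound 3 `COc1ccc(/C=N/NC(=O)Nc2cc3c(Nc4ccc(F)c(Cl)c4)ncnc3cc2O[C@H]2CCOC2)cc1` gives 28800 nM. Going by the values given here, the only single-point step, a 1.1-fold higher number from compound 2 to compound 3 (0.04 log units; within the scatter), lies within the scatter. Compound 4 `CCN(CC)c1ccc(/C=N/NC(=O)Nc2cc3c(Nc4ccc(F)c(Cl)c4)ncnc3cc2O[C@H]2CCOC2)c(O)c1` differs from compound 2 by 4-(diethylamino)-2-hydroxyphenyl in place of 4-cyanophenyl on a carbon with a double bond to nitrogen. Among the compounds with values here, no measured step involves the diethylamino or hydroxy groups, so the flat step from compound 2 to compound 3 is the only guide, and it suggests no movement beyond the scatter. Compound 4 is therefore expected to give about 25000 nM, with a range from 8000 nM to 80000 nM. The expected step of a 1.1-fold lower number from compound 2 to compound 4 (0.02 log units; within the scatter) is none beyond the scatter.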

Compound 4, half-maximal inhibitory concentration: 15700 nM
The estimate for compound 4 lay 1.6-fold (0.20 log units) above the measured number; the measured number falls inside the stated range.
By their numbers in this assay, from the lowest: compounds 4, 2 and 3 (each within the scatter of the next).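

In this assay, 4-(diethylamino)-2-hydroxyphenyl in place of 4-cyanophenyl gives a 1.7-fold lower number from compound 2 to compound 4 (0.23 log units; within the scatter), and in place of 4-methoxyphenyl it gives a 1.8-fold lower number from compound 3 to compound 4 (0.26 log units; within the scatter). The earlier compounds had not shown that this place, on a carbon with a double bond to nitrogen, could carry diethylamino and hydroxy together without a step beyond the scatter. Nothing measured here bears on why these numbers stay so close. The compounds shown leave open how diethylamino and hydroxy would each behave alone, and whether a carboxylic acid on that phenyl ring would give a step beyond the scatter.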